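The source may report more compounds than this note shows. Statements on the series, on what has been measured and on what is new or still open speak of the compounds shown alone.

In a functional assay on MDA-MB-231 cells (Homo sapiens) for cytotoxicity, read by MTT assay (on this read-out higher numbers stand for weaker inhibition and lower numbers for stronger inhibition), compound 1 `CCCOc1c(Br)cc(/C=C2\CCC/C(=C\c3cccc([N+](=O)[O-])c3)C2=O)cc1OC` gives 2.99 ug/mL and compound 2 `CCCCOc1c(Br)cc(/C=C2\CCC/C(=C\c3cccc([N+](=O)[O-])c3)C2=O)cc1OC` gives 5.53 ug/mL, so compound 2 stands level with compound 1 within the scatter. Among the compounds with values here, the only measured step, a 1.8-fold higher number from compound 1 to compound 2 (0.27 log units; within the scatter), adds a methyl to the saturated chain and leaves the nitrophenyl group untouched. Compound 3 `CCCCOc1c(Br)cc(/C=C2\CCC/C(=C\c3ccc([N+](=O)[O-])cc3)C2=O)cc1OC` differs from compound 2 by 4-nitrophenyl in place of 3-nitrophenyl on a double-bonded chain carbon bound to a double-bonded ring carbon. Within the data shown here, no measured step bears on this change, so no step beyond the scatter is expected in this assay, and the expectation rests on compound 2 at 5.53 ug/mL. The expected step is a 1.1-fold lower number from compound 2 to compound 3 (0.04 log units; within the scatter). For compound 3 the estimated value is 5 ug/mL, with an expected range of 2 ug/mL to 12 ug/mL.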

Compound 3, half-maximal inhibitory concentration: 8.38 ug/mL
For compound 3 the middle estimate is 1.7-fold (0.22 log units) below the measured one; measured number inside the range.
By their numbers in this assay, from the lowest: compounds 1, 2 and 3 (each within the scatter of the next, the first and the last beyond it).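

In this assay, within the data shown here, the first look at this position, 4-nitrophenyl in place of 3-nitrophenyl gives a 1.5-fold higher number from compound 2 to compound 3 (0.18 log units; within the scatter), so on this single pair the two nitrophenyl groups cannot be told apart. This holds only for the chain of compound 2 and says nothing about other groups at this place. No measured evidence bears on this result. The compounds shown leave open whether an amine or a nitrile in place of the nitro group would give a step beyond the scatter, and whether 4-nitrophenyl would read the same on the chain of compound 1.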